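Exchanging a Fluorine for a Nitrile on the Amide Aryl Ring

The source may report more compounds than this note shows. Statements on the series, on what has been measured and on what is new or still open speak of the compounds shown alone.

Compound 1, with the structure `CC(C)NC(=O)[C@H]1CC[C@@H](n2/c(=N/C(=O)c3ccc(F)c(F)c3)[nH]c3ccc(CN4CCC(C(C)(C)O)CC4)cc32)CC1`, is the steadiest of the three measured compounds in an in vitro ADME assay on microsomes from liver (Rattus norvegicus) for metabolic stability (a lower number here means slower removal, a higher number faster removal of the compound), giving 19 mL.min-1.g-1. Compound 2, `CC(C)NC(=O)[C@H]1CC[C@@H](n2/c(=N/C(=O)c3ccc(F)cc3)[nH]c3ccc(CN4CCCCC4)cc32)CC1`, gives 451 mL.min-1.g-1 in this assay, and compound 3, `COC(=O)[C@H]1CC[C@@H](n2/c(=N/C(=O)c3ccccc3)[nH]c3ccc(CN4CCCCC4)cc32)CC1`, gives 459 mL.min-1.g-1, so compound 1 is removed far more slowly than either of the others, and the gaps to both lie beyond the usual scatter.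

The next compound, compound 4, has the structure `CC(C)NC(=O)[C@H]1CC[C@@H](n2/c(=N/C(=O)c3cc(F)cc(C#N)c3)[nH]c3ccc(CN4CCC(C(C)(C)O)CC4)cc32)CC1`. It keeps the whole of compound 1 except for one change on the aryl ring that hangs off the amide carbonyl: 3-cyano-5-fluorophenyl in place of 3,4-difluorophenyl on a carbonyl carbon. Among the compounds with values here, nothing among the measured compounds isolates this particular swap, since compounds 2 and 3 differ from compound 1 in several places at once, so there is no directly comparable step to draw on.

With a single fluorine replaced by a nitrile and the other fluorine moved, the change is modest in size, and the expectation is for the step of a 1.5-fold higher number from compound 1 to compound 4 (0.17 log units; within the scatter) to stay close to compound 1, with any drift more likely upward than downward. Compound 4 is therefore estimated at 28 mL.min-1.g-1 in this assay, with a plausible range from 10 mL.min-1.g-1 to 75 mL.min-1.g-1.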

Compound 4, intrinsic clearance in microsomes: 30 mL.min-1.g-1
Estimate against measurement, compound 4: 1.1-fold (0.03 log units) below, and the stated range covers the measured number.
By their numbers in this assay, from the lowest: compounds 1 and 4 (each within the scatter of the next); then compounds 2 and 3 (each within the scatter of the next).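

In this assay, within the data shown here, this is the first comparison in which only the aryl ring on the carbonyl carbon changes: 3-cyano-5-fluorophenyl in place of 3,4-difluorophenyl gives a 1.6-fold higher number from compound 1 to compound 4 (0.20 log units; within the scatter), so the two compounds cannot be told apart in this assay. The exchange adds a nitrile and leaves one fluorine on the ring, yet the measured clearance stays within the usual scatter, which shows that this particular change, with the rest of compound 1 held fixed, does not alter the read-out measurably, though a single pair sets no general rule for this position. Nothing measured here explains why the number holds when the ring substituents change.

Still open, on these data alone, is whether the read-out would also hold with quite different groups on this aryl ring, such as a methoxy group, an amine or a carboxylic acid. Compounds 2 and 3 differ from compound 1 in several places at once, so the compounds shown also do not reveal which part of the structure accounts for the large gap between those two compounds and compound 1.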